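The source may report more compounds than this note shows. Statements on the series, on what has been measured and on what is new or still open speak of the compounds shown alone.

Measured compounds:
Compound 1, `CS(=O)(=O)Nc1cccc(-c2nc(C(c3ccc(F)cc3)c3ccc(F)cc3)sc2CC(=O)O)c1`, gives 40 nM in an in vitro assay on HEK385-7 cells for displacement of a labelled ligand from prostaglandin D2 receptor 2 (Homo sapiens); a lower number here means a stronger inhibitor, a higher number a weaker inhibitor.
Compound 2, `COc1cc(-c2nc(C(c3ccc(F)cc3)c3ccc(F)cc3)sc2CC(=O)O)ccn1`, gives 29 nM in this assay.

Going by the values given here, compound 2 holds the lower of the two numbers, yet the only measured step, a 1.4-fold lower number from compound 1 to compound 2 (0.14 log units; within the scatter), lies within the scatter, so the two compounds cannot be ordered. Compound 3, `CN(C)c1cc(-c2nc(C(c3ccc(F)cc3)c3ccc(F)cc3)sc2CC(=O)O)ccn1`, has not been measured. It differs from compound 2 by dimethylamino in place of methoxy on an aromatic carbon. Among the compounds with values here, no measured step touches this position: the step from compound 1 to compound 2 exchanges the whole aryl group, and it was itself small. There is therefore nothing in the data to point to a shift in either direction, and the expectation for compound 3 rests on compound 2 alone. Compound 3 is expected to sit close to compound 2, with a 1.2-fold higher number from compound 2 to compound 3 (0.08 log units; within the scatter) as the estimated step. The estimate for compound 3 in this assay is 35 nM, in a range from 12 nM to 100 nM.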

Compound 3, half-maximal inhibitory concentration: 380 nM
Beside the measured number, compound 3's estimate is 11-fold (1.04 log units) below it; the measured number lies above the stated range.
By their numbers in this assay, from the lowest: compounds 2 and 1 (each within the scatter of the next); then compound 3.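

In this assay, the group on the aromatic carbon next to the ring nitrogen proves far from indifferent: with only dimethylamino in place of methoxy, the result is a 13-fold higher number from compound 2 to compound 3 (1.12 log units; beyond the scatter). The earlier pair had not separated 2-methoxypyridin-4-yl from 3-(methanesulfonamido)phenyl, whereas 2-(dimethylamino)pyridin-4-yl also stands apart from the latter, with a 9.5-fold higher number from compound 1 to compound 3 (0.98 log units; beyond the scatter). Nothing available here explains this shift.

As far as these compounds go, it remains open whether the loss belongs to dimethylamino in particular or to any nitrogen attached at this carbon, a question that a primary amine, a methylamino group or a pyrrolidine at this place would address. From the compounds shown here alone, it is equally open whether a longer ether, such as ethoxy, would stay close to compound 2 at 29 nM.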